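This account rests on a few compounds, and the source may have more. Where it says the series, first, only, none or still open, it means among the compounds named here.

Compound 3 `COc1cc(N(C)C)c(NC(=O)c2ncccn2)cc1Nc1nccc(-c2cn(C)c3ccccc23)n1` stands second highest of the three numbers in a functional assay on NCI-H1975 cells (Homo sapiens) for antiproliferative activity, read by MTT assay, with a stated time of 72 h (a lower number here means a stronger inhibitor, a higher number a weaker inhibitor), where compound 3 gives 5400 nM. Compound 1 `COc1cc(N(C)C)c(NC(=O)c2ccncc2OC)cc1Nc1nccc(-c2cn(C)c3ccccc23)n1` gives 12100 nM in this assay, and compound 2 `COc1cc(N(C)C)c(NC(=O)c2ccncn2)cc1Nc1nccc(-c2cn(C)c3ccccc23)n1` gives 1250 nM. The measured steps are a 9.7-fold lower number from compound 1 to compound 2 (0.99 log units; beyond the scatter), a 2.2-fold lower number from compound 1 to compound 3 (0.35 log units; beyond the scatter) and a 4.3-fold higher number from compound 2 to compound 3 (0.64 log units; beyond the scatter). Compound 4 `COc1cc(N(C)C)c(NC(=O)c2ccnc(Cl)n2)cc1Nc1nccc(-c2cn(C)c3ccccc23)n1` differs from compound 3 in one place: 2-chloropyrimidin-4-yl in place of pyrimidin-2-yl on a carbonyl carbon. Among the compounds with values here, two measured steps bear on this change. The step of a 4.3-fold higher number from compound 2 to compound 3 (0.64 log units; beyond the scatter) shows the move from pyrimidin-4-yl to pyrimidin-2-yl, which compound 4 reverses, while the step of a 9.7-fold lower number from compound 1 to compound 2 (0.99 log units; beyond the scatter) shows the gain the pyrimidin-4-yl carbonyl gave over another ring. Within the data shown here, compound 4 carries the 2-chloropyrimidin-4-yl group where compound 2 carries pyrimidin-4-yl, and no measured pair shows what the added chlorine does, so the expectation rests mainly on compound 2. Compound 4 is therefore expected to give a lower number than compound 3 in this assay, with an expected step of a 3.6-fold lower number from compound 3 to compound 4 (0.56 log units; beyond the scatter). The estimate for compound 4 is 1500 nM, within a range from 500 nM to 5000 nM.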

Compound 4, half-maximal inhibitory concentration: 3660 nM
The estimate for compound 4 lay 2.4-fold (0.39 log units) below the measured number; measured number inside the range.
By their numbers in this assay, from the lowest: compound 2; then compounds 4 and 3 (each within the scatter of the next); then compound 1.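

In this assay, chloro in place of hydrogen on an aromatic carbon of the pyrimidin-4-yl group costs potency (a 2.9-fold higher number from compound 2 to compound 4 (0.47 log units; beyond the scatter)), the first measured sign of what this chlorine does. With the chlorine in place, the 2-chloropyrimidin-4-yl carbonyl can no longer be told apart from the pyrimidin-2-yl carbonyl (a 1.5-fold lower number from compound 3 to compound 4 (0.17 log units; within the scatter)), although it keeps a lower number than the 3-methoxypyridin-4-yl carbonyl (a 3.3-fold lower number from compound 1 to compound 4 (0.52 log units; beyond the scatter)). No measurement on hand gives a reason for the cost of the chlorine.

On these data alone, it remains open whether the loss is particular to chloro or would also follow from a methyl, a methoxy or an amine in its place. The compounds shown also leave open whether chloro on the pyrimidin-2-yl group would move the number in the same direction.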